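Swapping the Sulfonyl Aryl Group Across Two Matched Pairs

The compounds below may be only part of what the source reports. "The series", "measured", "known", "first", "only" and "open" are said of these compounds alone.

Measured compounds in an ADME assay on HEK-293T cells (Homo sapiens) for inhibition, read by CCK-8 assay, with a stated time of 48 h, tested at 20 uM; on this read-out higher numbers stand for more inhibition of growth at the one concentration tested and lower numbers for less inhibition of growth:
compound 1, `N#C/C(=C\c1ccccc1OS(=O)(=O)c1ccccc1[N+](=O)[O-])C(=O)Nc1nnc(Cc2ccccc2)s1`, gives 10%;
compound 2, `N#C/C(=C\c1ccccc1OS(=O)(=O)c1ccc(Cl)cc1)C(=O)Nc1nnc(Cc2ccccc2)s1`, gives 25%;
compound 3, `N#C/C(=C\c1ccccc1OS(=O)(=O)c1ccccc1[N+](=O)[O-])C(=O)Nc1nnc(Cc2ccc(Cl)cc2)s1`, gives 20%.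

Compound 1 and compound 2 differ only by 4-chlorophenyl in place of 2-nitrophenyl on a sulfonyl sulfur, and this change produced a number 15 percentage points higher from compound 1 to compound 2 (beyond the scatter). Compound 3 keeps the sulfonyl group of compound 1; its core differs from that of compound 1 by chloro in place of hydrogen on an aromatic carbon, a change that gave a number 10 percentage points higher from compound 1 to compound 3 (within the scatter), so the two cores cannot be told apart on this read-out.

Compound 4, `N#C/C(=C\c1ccccc1OS(=O)(=O)c1ccc(Cl)cc1)C(=O)Nc1nnc(Cc2ccc(Cl)cc2)s1`, has not yet been measured. It differs from compound 3 by 4-chlorophenyl in place of 2-nitrophenyl on a sulfonyl sulfur. This is the same change as that made from compound 1 to compound 2, at the same place, and it occurs twice among these four compounds. A step of similar size is expected on moving to compound 4, a number 15 percentage points higher from compound 3 to compound 4 (beyond the scatter), because the measured pair showed a number 15 percentage points higher from compound 1 to compound 2 (beyond the scatter). Going by the values given here, with only one pair to rest on, the bounds are kept wide. Compound 4 is therefore estimated to give 35% in this assay, between 20% and 50%.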

Compound 4, percent growth inhibition at one concentration: 14%
The estimate for compound 4 lay 21 percentage points above the measured number; measured number outside the range, below it.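

In this assay, 4-chlorophenyl in place of 2-nitrophenyl on the sulfonyl sulfur gave a number 6 percentage points lower from compound 3 to compound 4 (within the scatter), so the step seen on the core of compound 1 did not carry over to the core of compound 3: the same change on two cores in this assay, a number 15 percentage points higher (beyond the scatter) from compound 1 to compound 2 and a number 6 percentage points lower (within the scatter) from compound 3 to compound 4, 21 percentage points apart, beyond the scatter of two such steps

Read the other way round, chloro in place of hydrogen on an aromatic carbon gave a number 11 percentage points lower from compound 2 to compound 4 (beyond the scatter) when the sulfonyl group was (4-chlorophenyl)sulfonyl, so that step too changed with its partner group: the same change on two cores in this assay, a number 10 percentage points higher (within the scatter) from compound 1 to compound 3 and a number 11 percentage points lower (beyond the scatter) from compound 2 to compound 4, 21 percentage points apart, beyond the scatter of two such steps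

This shows that, in these four compounds, the two changes do not simply add up, but it rests on a single set of four compounds at one concentration and does not show why the steps differ or how the change would behave on any further core.

The compounds shown leave open whether a plain methyl on the sulfonyl sulfur would follow compound 2 or compound 4. They also leave open what a carboxylic acid or an amine would do in place of the chloro on the aromatic carbon.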